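The source may report more compounds than this note shows. Statements on the series, on what has been measured and on what is new or still open speak of the compounds shown alone.

Compound 1, `Cc1ccc(-c2ccc(NC3=CC(=O)c4ncncc4C3=O)cc2F)cc1`, gives 5000 nM in a functional assay on BXPC-3 cells (Homo sapiens) for cytotoxicity, read by MTT assay, with a stated time of 72 h; a higher number here means a weaker inhibitor, a lower number a stronger inhibitor; compound 2, `O=C1C(Nc2ccc(Oc3ccccc3)cc2)=CC(=O)c2ncncc21`, gives 3600 nM in the same assay.

On these two numbers compound 2 stands lowest, and its nearest neighbour is compound 1, whose number lies within the usual scatter of it, so the two compounds cannot be told apart on potency. Compound 1 carries a biaryl on the shared core, compound 2 a phenoxy, and nothing here separates the two arrangements.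

Compound 3, `O=C1C(Nc2ccc(-c3ccccc3)cc2)=CC(=O)c2ncncc21`, is not yet measured. It differs from compound 2 in one place: phenyl in place of phenoxy on an aromatic carbon. Going by the values given here, no measured pair isolates this change. Because compound 1, which also holds a biaryl, gives 5000 nM, no step beyond the scatter is expected, and the estimated step from compound 2 to compound 3 is a 1.3-fold higher number from compound 2 to compound 3 (0.10 log units; within the scatter). Compound 3 is therefore expected to give about 4500 nM in this assay, within a range from 1800 nM to 11000 nM.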

Compound 3, half-maximal inhibitory concentration: 500 nM
Compound 3: middle estimate off by 9.0-fold (0.95 log units), on the high side; measured number below the stated range.
By their numbers in this assay, from the lowest: compound 3; then compounds 2 and 1 (each within the scatter of the next).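

In this assay, phenyl in place of phenoxy on this aromatic carbon, para to a large group, gives a 7.2-fold lower number from compound 2 to compound 3 (0.86 log units; beyond the scatter), which is the first step beyond the scatter among these compounds. This position therefore responds to the group it carries, even though the change only takes out the oxygen of the phenoxy and leaves the outer six-membered aromatic ring of carbon in the molecule. The finding rests on this single pair, and no measurement at hand says why the number moves.

On these data alone, it remains open whether the lower number needs the phenyl directly on this carbon, or whether an amine or a methylene in place of the phenoxy oxygen would give a similar number. Also open, as far as these compounds go, is how a carboxylic acid or a methoxy on the phenyl of compound 3 would change the number.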